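Working notes: a methyl group on compound 3

The compounds below may be only part of what the source reports. "The series", "measured", "known", "first", "only" and "open" are said of these compounds alone.

For the measured compounds named here, in a functional assay on MCF7 cells (Homo sapiens) for antiproliferative activity, read by MTT assay, with a stated time of 48 h (a lower number here means a stronger inhibitor, a higher number a weaker inhibitor), compound 1 `COC(=O)[C@H](C)NC(=O)c1ccc(Oc2nc3ccccc3nc2NC(C)(C)C)cc1` gives 38400 nM as the only number. Compound 2 `COC(=O)[C@H](CC(C)C)NC(=O)c1ccc(Oc2nc3ccccc3nc2NC(C)(C)C)cc1` gives > 50000 nM as a limit of the assay. Compound 3 `CC(C)(C)Nc1nc2ccccc2nc1Oc1ccc(C(=O)NCC(=O)O)cc1` gives > 50000 nM as a limit too, so it has no number. Compound 4 `C[C@H](NC(=O)c1ccc(Oc2nc3ccccc3nc2NC(C)(C)C)cc1)C(=O)O` differs from compound 3 by methyl in place of hydrogen on a saturated chain carbon bound to an amide-type nitrogen and a carbonyl carbon and nothing else. Going by the values given here, two steps bear on this: an at least 1.3-fold higher number from compound 1 to compound 3 (0.11 log units; that floor lies within the scatter) and an at least 1.3-fold higher number from compound 1 to compound 2 (0.11 log units; that floor lies within the scatter) are both floors only. In this assay the expected step is a number no higher from compound 3 to compound 4 (the limit leaves the size open) with no change beyond the scatter expected. Compound 4 is estimated at 50000 nM with an expected range of 25000 nM to 100000 nM as its bounds.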

Compound 4, half-maximal inhibitory concentration: 29400 nM
For compound 4 the middle estimate is 1.7-fold (0.23 log units) above the measured one, and the stated range covers the measured number.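

In this assay, methyl on this saturated chain carbon gives the carboxylic acid series a measured number, but the step is only an at least 1.7-fold lower number from compound 3 to compound 4 (0.23 log units; that floor lies within the scatter). The comparison with the leucine-type ester gives an at least 1.7-fold lower number from compound 2 to compound 4 (0.23 log units; that floor lies within the scatter), and both steps remain floors because each starts from a limit: the limit of > 50000 nM in this assay, at which 2 of the 4 values shown sit. The methyl ester of compound 1 and the carboxylic acid of compound 4 differ by a 1.3-fold lower number from compound 1 to compound 4 (0.12 log units; within the scatter).

Open, from the compounds shown here alone, is whether a benzyl group or an amine-bearing chain on this carbon would shift this assay beyond the scatter.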